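This account rests on a few compounds, and the source may have more. Where it says the series, first, only, none or still open, it means among the compounds named here.

Working notes on the series. In a functional assay on A549 cells (Homo sapiens) for inhibition, read by CCK-8 assay, with a stated time of 72 h, tested at 10 uM (on this read-out lower numbers stand for less inhibition of growth and higher numbers for more inhibition of growth at the one concentration tested), compound 1 (`COC(=O)c1ccc(NC(=O)C2(C(=O)Nc3ccc(Nc4ncc5cc(C(=O)N(C)C)n(C6CCCC6)c5n4)cc3)CC2)cc1`) gives 92% and compound 2 (`CN(C)C(=O)c1cc2cnc(Nc3ccc(NC(=O)C4(C(=O)Nc5cccc(Br)c5)CC4)cc3)nc2n1C1CCCC1`) gives 92.2%, two values within the scatter of each other, so compound 2 cannot be separated from compound 1. The next compound is compound 3 (`CN(C)C(=O)c1cc2cnc(Nc3ccc(NC(=O)C4(C(=O)Nc5ccccc5)CC4)cc3)nc2n1C1CCCC1`), with this difference: hydrogen in place of bromo on an aromatic carbon. Among the measured compounds shown here, the one measured step on the same amide-type nitrogen is a number 0.2 percentage points higher from compound 1 to compound 2 (within the scatter). For the measured compounds named here, that step is small, but it compares two substituted rings, and no measured compound yet carries phenyl there, so the evidence is thin. A change beyond the scatter is therefore not expected in this assay, only a slight downward lean. The expected change is a number 3.2 percentage points lower from compound 2 to compound 3 (within the scatter). For compound 3 the estimated value is 89%, with an expected range from 78% to 96%.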

Compound 3, percent growth inhibition at one concentration: 88.8%
Estimate against measurement, compound 3: 0.2 percentage points above; measured number inside the range.
By their numbers in this assay, from the lowest: compounds 3, 1 and 2 (each within the scatter of the next).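

In this assay, phenyl itself now has a reading on this amide-type nitrogen, and taking the substituent off the ring does not separate the compounds: hydrogen in place of bromo gives a number 3.4 percentage points lower from compound 2 to compound 3 (within the scatter) and hydrogen in place of methoxycarbonyl gives a number 3.2 percentage points lower from compound 1 to compound 3 (within the scatter) on the same ring. Neither the 3-bromophenyl ring nor the 4-(methoxycarbonyl)phenyl ring is therefore shown to be required for growth inhibition at this one concentration, and the three compounds cannot be ranked. Nothing available accounts for this flat result.

The compounds shown leave open whether a carboxylic acid or an amine on this ring would give a change beyond the scatter. They also leave open what a longer alkyl chain in place of the phenyl ring would do on this nitrogen.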